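Heptyl to trifluoromethyl on a shared urea core

The source may report more compounds than this note shows. Statements on the series, on what has been measured and on what is new or still open speak of the compounds shown alone.

Among the measured compounds shown here, compound 2 `CCCCCCCc1ccc(NC(=O)N[C@H](C)c2ccccc2)cc1` gives 100% in an ADME assay on the whole organism with Oryza sativa as the target, tested at 10 uM (a lower number here means a stronger effect, a higher number a weaker effect of the compound at the concentration tested), the highest of the two numbers measured so far. For the measured compounds named here, compound 1 `CCCCc1ccc(NC(=O)N[C@H](C)c2ccccc2)cc1` gives 28% in this assay, and the step of a number 72 percentage points higher from compound 1 to compound 2 (beyond the scatter) is the only measured step that bears on the move to compound 3 `C[C@@H](NC(=O)Nc1ccc(C(F)(F)F)cc1)c1ccccc1`. That move is trifluoromethyl in place of heptyl on an aromatic carbon. The rise on lengthening the chain was large, so the step to trifluoromethyl is expected to lower the number by a large step, estimated as a number 60 percentage points lower from compound 2 to compound 3 (beyond the scatter). Compound 3 is therefore expected to give 40% in this assay, within 10% to 80%.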

Compound 3, a percentage reported as activity, at one concentration (the size of the read-out at that concentration, not a potency): 82%
Estimate against measurement, compound 3: 42 percentage points below; measured number outside the range, above it.
By their numbers in this assay, from the lowest: compound 1; then compound 3; then compound 2.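

Replacing the alkyl chain with trifluoromethyl on this aromatic carbon does not return the number to that of the butyl compound: in this assay there is a number 18 percentage points lower from compound 2 to compound 3 (beyond the scatter) but also a number 54 percentage points higher from compound 1 to compound 3 (beyond the scatter). Compound 3 thus stands nearer to the heptyl compound than to the butyl compound, although trifluoromethyl is the smaller group of the pair it replaces here. Nothing available accounts for this result. As far as these compounds go, whether a methyl, a nitrile or an amine at this carbon would fall near compound 1 or near compound 2 remains open. So does the behaviour of a pentyl or hexyl chain, which would lie between butyl and heptyl.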